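This account rests on a few compounds, and the source may have more. Where it says the series, first, only, none or still open, it means among the compounds named here.

Measured so far:
compound 1 `O=C(O)c1ccc(Cl)cc1-c1ccc2c(c1)OC[C@H](Cc1ccc(F)cc1)[C@H]2O`: 54 nM
compound 2 `O=S(=O)(Nc1ccc(F)cc1-c1ccc2c(c1)OC[C@H](Cc1ccccc1)[C@H]2O)C(F)(F)F`: 50 nM; 3.8 nM (2 entries)
compound 3 `O=C(O)c1ccc(Cl)cc1-c1ccc2c(c1)OC[C@H](Cc1ccc(-c3ccccc3)cc1)[C@H]2O`: 8 nM; 4 nM (2 entries)

Within the data shown here, in an assay on isolated protein for binding affinity to leukotriene B4 receptor (Homo sapiens) (on this read-out lower numbers stand for stronger inhibition and higher numbers for weaker inhibition), compound 1 gives 54 nM, the only single number in this set, whereas compound 2 and compound 3 each carry several entries, as the several entries of compound 2 in this assay, 50 nM; 3.8 nM (2 entries) and the several entries of compound 3 in this assay, 8 nM; 4 nM (2 entries) show. Compound 4 `O=C(O)c1ccc(Cl)cc1-c1ccc2c(c1)OC[C@H](Cc1ccc3ccccc3c1)[C@H]2O` has not been measured yet. It differs from compound 1 in one place: naphthalen-2-yl in place of 4-fluorophenyl on a saturated chain carbon bound to a saturated ring carbon. Among the measured compounds shown here, no measured pair shows this exact change, so its step size is unknown. A step toward stronger binding, beyond the scatter, is nevertheless expected, because compound 3 gives 8 nM; 4 nM (2 entries), a lower number than compound 1. The expected step from compound 1 to compound 4 is a 4.5-fold lower number from compound 1 to compound 4 (0.65 log units; beyond the scatter). Compound 4 is thus estimated at 12 nM, between 3 nM and 45 nM.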

Compound 4, half-maximal inhibitory concentration: 100 nM
Compound 4: the middle estimate sits 8.3-fold (0.92 log units) below what was measured; the whole stated range lies below it.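

In this assay, the swap at this place gives a 1.9-fold higher number from compound 1 to compound 4 (0.27 log units; within the scatter), so 4-fluorophenyl and the larger naphthalen-2-yl cannot be told apart here. This place on the saturated chain carbon therefore accepts a second fused aromatic ring without a clear change in the number. Yet having two aromatic rings here does not by itself bring the low numbers of compound 3, which carries a 4-phenylphenyl group: the several entries of compound 3 in this assay, 8 nM; 4 nM (2 entries)

Still open, going by these compounds, is how a non-aromatic ring such as cyclohexyl, or a longer chain ending in phenyl, would behave at this same place.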